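The source may report more compounds than this note shows. Statements on the series, on what has been measured and on what is new or still open speak of the compounds shown alone.

Compound 1 `N[C@H]1CCCN(c2cccc(-c3n[nH]c4cnc(-c5cccnc5)cc34)n2)C1`: 48%
Compound 2 `Cc1cncc(-c2cn3c(-c4cccc(N5CCCNCC5)n4)ncc3cn2)n1`: 69%
Compound 3 `Cc1cncc(-c2ccc3cnn(-c4cccc(N5CCCNCC5)n4)c3c2)n1`: 100%

In an ADME assay on microsomes from intestine (Rattus norvegicus) for metabolic stability, with a stated time of 60 min, in the presence of a further agent that is not named here (on this read-out higher numbers stand for a more stable compound and lower numbers for a less stable compound), compound 1 gives 48%, the lowest of the three numbers. Compound 2 gives 69%, a gap beyond the scatter, and compound 3 gives 100%, further still. Compound 4 `Cn1nc(-c2cccc(N3CCC[C@H](N)C3)n2)c2cc(-c3cccnc3)ncc21` differs from compound 1 in a single place: methyl in place of hydrogen on an aromatic nitrogen. Among the compounds with values here, no pair of measured compounds differs in just one place, so the numbers give no direct measure of what such a change does in this assay. The change adds one carbon and removes a hydrogen from the ring nitrogen, and compound 4 is expected to end up close to compound 1 in this assay, with a step of a number 7 percentage points higher from compound 1 to compound 4 (within the scatter) that may sit within the scatter. The estimate for compound 4 is therefore 55%, with a range from 30% to 80%.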

Compound 4, percent of the compound remaining: 103%
The estimate for compound 4 lay 48 percentage points below the measured number, outside the stated range (above it).
By their numbers in this assay, from the lowest: compound 1; then compound 2; then compounds 3 and 4 (each within the scatter of the next).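

In this assay, methyl in place of hydrogen on an aromatic nitrogen gives a number 55 percentage points higher from compound 1 to compound 4 (beyond the scatter) and so counts as a large step. Within the data shown here, this shows that a change of one heavy atom at this ring nitrogen can shift the percent remaining far beyond the scatter, something the earlier compounds, with no pair differing in one place, could not show. No measurement shown here explains the step. From the compounds shown here alone, whether ethyl, a longer chain or an acetyl group on this nitrogen would give a similar number remains open. One pair also cannot tell whether methyl would have the same effect on another core.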